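Hydroxymethyl to methylcarbamoyl: expected clearance of compound 4

The compounds below may be only part of what the source reports. "The series", "measured", "known", "first", "only" and "open" are said of these compounds alone.

Measured in an in vitro ADME assay on microsomes from liver (Homo sapiens) for metabolic stability, tested at 1 uM; on this read-out higher numbers stand for fast clearance and lower numbers for slow clearance:
- compound 1 `Cc1cc(/C=C/C#N)cc(C)c1Oc1cc(Nc2ccc(C#N)cc2)c(N)cc1C(N)=O`: 200 mL.min-1.g-1
- compound 2 `COC(=O)c1cc(N)c(Nc2ccc(C#N)cc2)cc1Oc1c(C)cc(/C=C/C#N)cc1C`: 20 mL.min-1.g-1
- compound 3 `Cc1cc(/C=C/C#N)cc(C)c1Oc1cc(Nc2ccc(C#N)cc2)c(N)cc1CO`: 230 mL.min-1.g-1

Compound 3 stands at 230 mL.min-1.g-1. Against the other two measured compounds, the steps are a 1.2-fold higher number from compound 1 to compound 3 (0.06 log units; within the scatter) and a 12-fold higher number from compound 2 to compound 3 (1.06 log units; beyond the scatter). The next compound is compound 4 `CNC(=O)c1cc(N)c(Nc2ccc(C#N)cc2)cc1Oc1c(C)cc(/C=C/C#N)cc1C`, with methylcarbamoyl in place of hydroxymethyl on an aromatic carbon.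

The nearest measured group is the carbamoyl of compound 1, at 200 mL.min-1.g-1. Its exchange for hydroxymethyl is a 1.2-fold higher number from compound 1 to compound 3 (0.06 log units; within the scatter), so these two groups do not separate in this assay. Only methoxycarbonyl stands apart, with a 10-fold lower number from compound 1 to compound 2 (1.00 log units; beyond the scatter). Within the data shown here, no measured compound carries methylcarbamoyl, and that leaves the estimate resting on the carbamoyl comparison alone.

The expected step is a 1.2-fold lower number from compound 3 to compound 4 (0.08 log units; within the scatter), and none beyond the scatter is anticipated. For compound 4 the estimated value is 190 mL.min-1.g-1, with an expected range of 80 mL.min-1.g-1 to 420 mL.min-1.g-1.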

Compound 4, intrinsic clearance in microsomes in the Homo sapiens assay: 150 mL.min-1.g-1
Compound 4: middle estimate off by 1.3-fold (0.10 log units), on the high side; measured number inside the range.
By their numbers in the Homo sapiens assay, from the lowest: compound 2; then compounds 4, 1 and 3 (each within the scatter of the next).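

In the Homo sapiens assay, methylcarbamoyl does not separate from hydroxymethyl at this position (a 1.5-fold lower number from compound 3 to compound 4 (0.19 log units; within the scatter)), and methyl on the amide-type nitrogen does not separate it from carbamoyl (a 1.3-fold lower number from compound 1 to compound 4 (0.12 log units; within the scatter)). Among the four compounds, methoxycarbonyl alone stands apart, and methylamino in place of methoxy on the carbonyl carbon restores the higher clearance (a 7.5-fold higher number from compound 2 to compound 4 (0.88 log units; beyond the scatter)). In a physicochemical assay for solubility, with a stated time of 4 h, at pH 2.0 (on this read-out lower numbers stand for lower solubility and higher numbers for higher solubility), compound 3 gives 20.9 ug/mL and compound 4 gives 8.63 ug/mL. Hydroxymethyl and methylcarbamoyl, alike in clearance, do part in the physicochemical assay: the measured solubility of compound 3, 20.9 ug/mL, and of compound 4, 8.63 ug/mL, a 2.4-fold lower number (0.38 log units; beyond the scatter)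

As far as these compounds go, whether the low clearance of compound 2 extends to an ethyl ester, or whether a carboxylic acid or an amine at this position would fall nearer compound 2 or compound 4, remains open. The compounds shown also leave open whether the solubility gap follows the amide carbonyl or the methyl on its nitrogen.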